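Series notes: a larger branch on the saturated ring carbon

A few compounds are considered here, and "the series" means these few. Any claim that something is new, unique, unknown or untested is made for them only; others in the source may bear on it.

Of the compounds shown here, two have numbers so far. Compound 1 `CCCN1CC(=O)N(Cc2ccc(C(=O)NO)cc2)C1=O` gives 53.4 nM in an assay on isolated protein for inhibition of protein deacetylase HDAC6 (Homo sapiens), read by fluorescence, with stated times of 10 min and 2 h; a higher number here means a weaker inhibitor, a lower number a stronger inhibitor. Compound 2 `CC1(c2ccccc2)NC(=O)N(Cc2ccc(C(=O)NO)cc2)C1=O` gives 74.9 nM in this assay. Compound 2 stands with the higher of the two numbers, compound 1 is its nearest neighbour, and the gap between them lies within the scatter, so no order between the two can be claimed. Compound 3 `CC(C)(C)c1ccc(CC2(c3ccccc3)NC(=O)N(Cc3ccc(C(=O)NO)cc3)C2=O)cc1` has not yet been measured in this assay. It differs from compound 2 by 4-(tert-butyl)phenyl in place of hydrogen on a saturated chain carbon bound to a saturated ring carbon. For the measured compounds named here, no step between measured compounds of this kind is available, so the size of this step cannot be read from the data. The expected step of a 1.5-fold lower number from compound 2 to compound 3 (0.18 log units; within the scatter) is no larger than the scatter, in the direction of a somewhat lower number. For compound 3 a value of 50 nM is estimated in this assay, with a range from 15 nM to 200 nM.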

Compound 3, half-maximal inhibitory concentration: 115 nM
Estimate against measurement, compound 3: 2.3-fold (0.36 log units) below; low and high end bracket the measured number.
By their numbers in this assay, from the lowest: compounds 1, 2 and 3 (each within the scatter of the next, the first and the last beyond it).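

In this assay, for the compounds shown here, the first step at this position reads a 1.5-fold higher number from compound 2 to compound 3 (0.19 log units; within the scatter) and so shows that replacing methyl with 4-(tert-butyl)benzyl, which adds a six-membered aromatic ring and 10 heavy atoms on a saturated chain carbon bound to a saturated ring carbon, gives no change beyond the scatter. This single pair shows that the position accepts this large branch with the hydroxamic acid side of the molecule unchanged, although it sets no upper limit on branch size and gives no trend. No measured evidence here bears on why the step stays this small. Open, as far as these compounds go, is whether plain benzyl, without the tert-butyl group, gives a step of similar size. Also open, from the compounds shown here alone, is how a polar group on the same branch, such as an amine or a carboxylic acid, would read at this position.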